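From a Propyl Urea to a Cyclopropyl Amide

This account rests on a few compounds, and the source may have more. Where it says the series, first, only, none or still open, it means among the compounds named here.

Compound 1 `CCCNC(=O)Nc1n[nH]c2c1CN(C(=O)C1CCN(C)CC1)C2(C)C` was measured in a physicochemical assay for solubility, at pH 7; a higher number here means a more soluble compound, a lower number a less soluble compound. In this assay compound 1 gives > 225000 nM, which is a limit of the assay and not a number. The two further compounds fare the same way. Compound 2 `CCN1CCC(C(=O)N2Cc3c(NC(=O)c4ccc(F)cc4)n[nH]c3C2(C)C)CC1` gives > 225000 nM in this assay, again a limit. Compound 3 `CN1CCN(C(=O)N2Cc3c(NC(=O)c4ccc(F)cc4)n[nH]c3C2(C)C)CC1` gives > 225000 nM, also a limit. Among the compounds with values here, the one step between measured compounds that differ in a single place, a step that the two limits leave unreadable from compound 2 to compound 3, therefore stays unreadable, and all three values sit at the same ceiling (the limit of > 225000 nM in this assay, at which 3 of the 3 values shown sit). Compound 4 `CN1CCC(C(=O)N2Cc3c(NC(=O)C4CC4)n[nH]c3C2(C)C)CC1` has not yet been measured. It differs from compound 1 by cyclopropyl in place of propylamino on a carbonyl carbon. Within the data shown here, no measured step touches this change, so its size cannot be read from the data; what the three compounds do show is that every member of this series so far reaches the ceiling. Compound 4 is therefore expected to behave alike, with an expected step of a number no higher from compound 1 to compound 4 (the limit leaves the size open) of no size beyond the scatter. Compound 4 is estimated at 225000 nM, within 90000 nM to 500000 nM, and will most likely be reported as a limit once more.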

Compound 4, solubility: > 225000 nM
Compound 4: only a limit was reported; the forecaster's own chance of this, stated with the estimate: 75%; the middle value lies on the limit itself.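

Compound 4 gives > 225000 nM in this assay, again a limit and not a number. No new step can be read, and the change from compound 1 to compound 4 stays without a size: the limit of > 225000 nM in this assay, at which 4 of the 4 values shown sit. The compounds shown leave open where any of them would lie without this limit, and so what cyclopropyl in place of propylamino does in this assay.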